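Replacing the 4-(dimethylamino)piperidin-1-yl group of compound 2

This account rests on a few compounds, and the source may have more. Where it says the series, first, only, none or still open, it means among the compounds named here.

Among the compounds with values here, in a functional assay on NCI-H460 cells (Homo sapiens) for inhibition, read by sulforhodamine B assay, with a stated time of 72 h (a lower number here means a stronger inhibitor, a higher number a weaker inhibitor), compound 1 (`CCNC(=O)c1nnn(-c2cc(C(C)C)c(O)cc2O)c1-c1ccc(CN2CCN(C)CC2)cc1`) gives 47 nM and compound 2 (`CCNC(=O)c1nnn(-c2cc(C(C)C)c(O)cc2O)c1-c1ccc(CN2CCC(N(C)C)CC2)cc1`) gives 120 nM as the higher of the only two numbers available. Compound 3 (`CCNC(=O)c1nnn(-c2cc(C(C)C)c(O)cc2O)c1-c1ccc(CNC2CCCCC2)cc1`) has not yet been measured. It carries cyclohexylamino in place of 4-(dimethylamino)piperidin-1-yl on a saturated chain carbon bound to an aromatic carbon. Within the data shown here, one measured step bears on this change, made at the same place: a 2.6-fold higher number from compound 1 to compound 2 (0.41 log units; beyond the scatter) with 4-(dimethylamino)piperidin-1-yl in place of 4-methylpiperazin-1-yl. Among the measured compounds shown here, no compound with cyclohexylamino has a measured value, so the direction is uncertain. A modest change is expected, leaning slightly towards a higher number, and the estimated step is a 1.3-fold higher number from compound 2 to compound 3 (0.10 log units; within the scatter) in this case. Compound 3 is expected to give about 150 nM in this assay (estimated range 50 nM to 450 nM).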

Compound 3, half-maximal inhibitory concentration: 15 nM
The estimate for compound 3 lay 10-fold (1.00 log units) above the measured number, outside the stated range (below it).
By their numbers in this assay, from the lowest: compound 3; then compound 1; then compound 2.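

In this assay, cyclohexylamino on a saturated chain carbon bound to an aromatic carbon gives an 8.0-fold lower number from compound 2 to compound 3 (0.90 log units; beyond the scatter) and also a 3.1-fold lower number from compound 1 to compound 3 (0.50 log units; beyond the scatter), so this position allows lower numbers than either 4-methylpiperazin-1-yl or 4-(dimethylamino)piperidin-1-yl had shown. Compared with the group in compound 2, the change alters several features at once: the ring is of carbon only, there is 1 hydrogen-bond donor instead of 0, and there are 7 heavy atoms instead of 9. No measurement available here explains the lower number or shows which of these features matters.

Going by these compounds, it remains open whether the hydrogen-bond donor or the carbon-only ring accounts for the step. A piperidin-1-yl group, which keeps a six-membered ring but has no amine hydrogen, and a cyclopentylamino group, which keeps that hydrogen on a smaller ring, would each test one part of the question.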